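The source may report more compounds than this note shows. Statements on the series, on what has been measured and on what is new or still open speak of the compounds shown alone.

Compound 3, `CCOC(=O)C1=C(Nc2cccc(F)c2)S/C(=C\c2ccc[nH]2)C1=O`, was tested in a functional assay on A549 cells (Homo sapiens) for inhibition, read by MTT assay, with a stated time of 72 h, tested at 10 uM; a lower number here means less inhibition, a higher number more inhibition at the concentration tested (going by the name of the read-out). In this assay compound 3 gives < 10%, which is a limit of the assay rather than a number. Two close relatives are also measured: compound 1, `CCOC(=O)C1=C(Nc2ccc(OC)cc2)S/C(=C\c2ccc[nH]2)C1=O`, and compound 2, `CCOC(=O)C1=C(Nc2ccc(F)cc2)S/C(=C\c2ccc[nH]2)C1=O`. In this assay compound 1 gives < 10%, a limit. In this assay compound 2 gives < 10%, again a limit. All three rest at the limit of < 10% in this assay, at which 3 of the 3 values shown sit, so the steps a step that the two limits leave unreadable from compound 1 to compound 2, a step that the two limits leave unreadable from compound 1 to compound 3 and a step that the two limits leave unreadable from compound 2 to compound 3 cannot be sized. Compound 4, `CCOC(=O)C1=C(Nc2ccc(C)cc2)S/C(=C\c2ccc[nH]2)C1=O`, carries 4-methylphenyl in place of 3-fluorophenyl on an amine nitrogen. For the measured compounds named here, no measured step bears readably on this change. Compound 4 is expected to remain at the limit, an estimated step that the limit leaves unreadable from compound 3 to compound 4. The estimate for compound 4 is 5%, between 0% and 15%.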

Compound 4, a percentage reported as inhibition, at one concentration (the size of the read-out at that concentration, not a potency): 20.9%
The estimate for compound 4 lay 15.9 percentage points below the measured number, outside the stated range (above it).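

For the compounds shown here, on the amine nitrogen, 4-methylphenyl gives the first readable number in this assay, so a change at this place can lift the read-out clear of the limit. Methyl in place of fluoro gives a number at least 10.9 percentage points higher from compound 2 to compound 4 (beyond the scatter), methyl in place of methoxy gives a number at least 10.9 percentage points higher from compound 1 to compound 4 (beyond the scatter), and 4-methylphenyl in place of 3-fluorophenyl gives a number at least 10.9 percentage points higher from compound 3 to compound 4 (beyond the scatter). Compound 4 alone stands off the limit: the limit of < 10% in this assay, at which 3 of the 4 values shown sit.

Going by these compounds, the true size of these steps stays open, as the other three values are limits. The compounds shown also leave open what an ethyl group or an amine in place of the methyl would give.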